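Methyl for chloro on the aryl thiourea: two measured cases

The source may report more compounds than this note shows. Statements on the series, on what has been measured and on what is new or still open speak of the compounds shown alone.

Measured so far in a functional assay on L1210 cells (Mus musculus), with a stated time of 48 h; on this read-out lower numbers stand for stronger inhibition and higher numbers for weaker inhibition:
compound 1 `O=C1Nc2ccc(Br)cc2/C1=N/NC(=S)Nc1ccc(Cl)cc1`: 88000 nM
compound 2 `Cc1ccc(NC(=S)N/N=C2\C(=O)Nc3ccc(Br)cc32)cc1`: 9600 nM
compound 3 `O=C1Nc2cc(Cl)c(F)cc2/C1=N/NC(=S)Nc1ccc(Cl)cc1`: 69000 nM

Compounds 1 and 2 share one core and differ by methyl in place of chloro on an aromatic carbon. That change gave a 9.2-fold lower number from compound 1 to compound 2 (0.96 log units; beyond the scatter). Compound 3 carries a different core; how the two cores differ is not broken down here, and the values of compound 3 and compound 1 lie within the usual scatter of each other. Compound 4 `Cc1ccc(NC(=S)N/N=C2\C(=O)Nc3cc(Cl)c(F)cc32)cc1` is not yet measured; it differs from compound 3 by methyl in place of chloro on an aromatic carbon, the same change as from compound 1 to compound 2 at the same kind of place. The expectation for compound 4 is a step of an 8.6-fold lower number from compound 3 to compound 4 (0.94 log units; beyond the scatter) in this assay, resting on the one earlier case, because the step from compound 1 to compound 2 was a 9.2-fold lower number from compound 1 to compound 2 (0.96 log units; beyond the scatter) and the cores of compound 1 and compound 3 gave values within the scatter of each other. Compound 4 is therefore estimated at 8000 nM, with a range of 3000 nM to 25000 nM in this assay.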

Compound 4, half-maximal inhibitory concentration: 166000 nM
For compound 4 the middle estimate is 21-fold (1.32 log units) below the measured one; measured number outside the range, above it.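

In this assay the change from 4-chlorophenyl to 4-methylphenyl gave a 2.4-fold higher number from compound 3 to compound 4 (0.38 log units; beyond the scatter) and so ran opposite in direction to the earlier case. The step therefore does not carry over unchanged between these two cores: the same change on two cores in this assay, a 9.2-fold lower number (0.96 log units; beyond the scatter) from compound 1 to compound 2 and a 2.4-fold higher number (0.38 log units; beyond the scatter) from compound 3 to compound 4, 22-fold (1.34 log units) apart, beyond the scatter of two such steps

Among these compounds, with only one pair on each core, this shows that the outcome of the change differs with the core, but not which difference between the cores matters, nor how the change would behave on any further core.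

Still open, as far as these compounds go, is whether the bromo substituent or the chloro and fluoro substituents on the core govern the direction of the step. Also open, from the compounds shown here alone, is how methoxy or an amine would compare with methyl and chloro at this place.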